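The source may hold more compounds than are shown below. What is called first, only, known or untested is meant among the compounds shown, and "the series" means these compounds.

Measured so far in the series:

Compound 1, `O=C(Nc1cccc(-c2oc3cc(-c4ccc(F)cc4)ccc3c(=O)c2O)c1)c1ccccc1F`: 7240 nM
Compound 2, `O=C(Nc1cccc(-c2oc3cc(-c4ccc(F)cc4)ccc3c(=O)c2O)c1)c1ccc(Br)cc1`: 24900 nM
Compound 3, `Cc1cccc(C(=O)Nc2cccc(-c3oc4cc(-c5ccc(F)cc5)ccc4c(=O)c3O)c2)c1`: 2840 nM

All three share one core and differ only in the ring on the carbonyl carbon of the amide. Read in a functional assay on MDA-MB-231 cells (Homo sapiens) for antiproliferative activity, read by CCK-8 assay, with a stated time of 72 h (on this read-out higher numbers stand for weaker inhibition and lower numbers for stronger inhibition), compound 2 stands highest of the three numbers: compound 1 sits nearest, the step of a 3.4-fold higher number from compound 1 to compound 2 (0.54 log units; beyond the scatter), and compound 3 furthest, the step of an 8.8-fold lower number from compound 2 to compound 3 (0.94 log units; beyond the scatter). Between the other two, a 2.5-fold lower number from compound 1 to compound 3 (0.41 log units; beyond the scatter).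

Compound 4, `CCCc1ccc(C(=O)Nc2cccc(-c3oc4cc(-c5ccc(F)cc5)ccc4c(=O)c3O)c2)cc1`, has not been measured. It differs from compound 2 by one change: propyl in place of bromo on an aromatic carbon.

Within the data shown here, the steps that bear on it are those leaving the 4-bromophenyl of compound 2. Both point downward: an 8.8-fold lower number from compound 2 to compound 3 (0.94 log units; beyond the scatter) swaps the bromo-bearing ring for a 3-methylphenyl, and the reverse of a 3.4-fold higher number from compound 1 to compound 2 (0.54 log units; beyond the scatter) returns to 2-fluorophenyl. Among the measured compounds shown here, no measured pair tests propyl itself, nor a group held para to a large group other than bromo, so the size is uncertain. A lower number than compound 2 in this assay is expected, of modest size, a 4.2-fold lower number from compound 2 to compound 4 (0.62 log units; beyond the scatter). Compound 4 is therefore estimated at 6000 nM, within 1800 nM to 20000 nM.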

Compound 4, half-maximal inhibitory concentration: 32200 nM
Compound 4: the middle estimate sits 5.4-fold (0.73 log units) below what was measured; the whole stated range lies below it.
By their numbers in this assay, from the lowest: compound 3; then compound 1; then compounds 2 and 4 (each within the scatter of the next).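

In this assay, propyl in place of bromo on an aromatic carbon para to a large group gives a 1.3-fold higher number from compound 2 to compound 4 (0.11 log units; within the scatter), so bromo and propyl are not told apart at this place. The 4-propylphenyl ring also stands clear of the other two rings, with an 11-fold higher number from compound 3 to compound 4 (1.05 log units; beyond the scatter) and a 4.4-fold higher number from compound 1 to compound 4 (0.65 log units; beyond the scatter); across these four compounds, the high numbers go with the 4-bromophenyl and 4-propylphenyl rings, and none of the four goes against this. Nothing available accounts for the match between bromo and propyl or for the gap to the other two rings.

Still open, on these data alone, is whether the high numbers hold for any group at this place or only for these two, a question that a hydroxyl, an amine or a carboxylic acid on the same carbon would put to the test. Also open, as far as these compounds go, is whether the lower number of compound 3 belongs to the methyl group or to where it sits, which an unsubstituted phenyl, a 4-methylphenyl and a 3-propylphenyl would help to separate.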